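The compounds below may be only part of what the source reports. "The series", "measured", "known", "first", "only" and "open" are said of these compounds alone.

For the measured compounds named here, only two compounds with this shared core have numbers so far in a functional assay on MDA-MB-231 cells (Homo sapiens) for antiproliferative activity, read by MTT assay, with a stated time of 24 h; a higher number here means a weaker inhibitor, a lower number a stronger inhibitor. Compound 1 `COc1cccc(Nc2ccnc(N3CCN(C(=O)Nc4ccc(C(F)(F)F)cc4)CC3)n2)c1` gives 1240 nM. Compound 2 `COc1cccc(Nc2ccnc(N3CCN(C(=O)Nc4ccccc4Cl)CC3)n2)c1` gives 5260 nM, the higher of the two numbers and so the weaker result. Compound 3 `COc1cccc(Nc2ccnc(N3CCN(C(=O)Nc4ccc(Cl)cc4Cl)CC3)n2)c1` differs from compound 2 at one place: chloro in place of hydrogen on an aromatic carbon. In words, chloro replaces hydrogen on an aromatic carbon, turning 2-chlorophenyl into 2,4-dichlorophenyl.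

Going by the values given here, only one measured step bears on this change: a 4.2-fold higher number from compound 1 to compound 2 (0.63 log units; beyond the scatter), with 2-chlorophenyl in place of 4-(trifluoromethyl)phenyl. That step alters two places at once, so it is a weak guide. Still, compound 1 also has a group para to a large group, and it holds the lower number. A smaller step in the same downward direction therefore seems likely in this assay. The expected change is a 2.1-fold lower number from compound 2 to compound 3 (0.32 log units; beyond the scatter). For compound 3 the estimated value is 2500 nM, with an expected range from 1000 nM to 6000 nM.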

Compound 3, half-maximal inhibitory concentration: 11300 nM
Compound 3: middle estimate off by 4.5-fold (0.66 log units), on the low side; measured number outside the range, above it.
By their numbers in this assay, from the lowest: compound 1; then compound 2; then compound 3.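

In this assay, adding chloro to the 2-chlorophenyl group gives a 2.1-fold higher number from compound 2 to compound 3 (0.33 log units; beyond the scatter), so here a new group para to a large group goes with a weaker result, not a stronger one. Compound 1 also carries a group at that place, yet the change to 2,4-dichlorophenyl gives a 9.1-fold higher number from compound 1 to compound 3 (0.96 log units; beyond the scatter), so the mere presence of a group there does not set the number. No measurement shown here explains why the added chloro goes with the higher number.

A 4-chlorophenyl group would show whether chloro at this place raises the number by itself or only alongside the second chloro. As far as these compounds go, how a methoxy group or an amine at the same place would compare remains open.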